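Swapping the aryl ether on a lactone ester

The source may hold more compounds than are shown below. What is called first, only, known or untested is meant among the compounds shown, and "the series" means these compounds.

Compound 1 `C=C1C(=O)O[C@@H]2CC(C)=C([C@@H](C)CCCOC(C)=O)[C@@H](OC(=O)CN(CC)CC)[C@H]12`: 11600 nM
Compound 2 `C=C1C(=O)O[C@@H]2CC(C)=C([C@@H](C)CCCOC(C)=O)[C@@H](OC(=O)COc3ccc(C(=O)OCCC)cc3)[C@H]12`: 27700 nM

Both compounds share one core and differ only in the ester attached to it. In a functional assay on SGC-7901 cells (Homo sapiens) for cytotoxicity, read by sulforhodamine B assay, with a stated time of 72 h (a lower number here means a stronger inhibitor, a higher number a weaker inhibitor), compound 2 gives the higher of the two numbers, the weaker of the pair. Compound 3 `C=C1C(=O)O[C@@H]2CC(C)=C([C@@H](C)CCCOC(C)=O)[C@@H](OC(=O)COc3cccc4cccnc34)[C@H]12` differs from compound 2 by quinolin-8-yl in place of 4-(propoxycarbonyl)phenyl on an oxygen on a saturated carbon. Going by the values given here, no pair measured here shows the effect of such a swap, so the expectation rests on the two values alone. The step from compound 2 to compound 3 is expected to be small, toward a lower number, roughly a 1.8-fold lower number from compound 2 to compound 3 (0.27 log units; within the scatter), possibly no further than the scatter. Compound 3 is therefore estimated at 15000 nM, in a range from 5000 nM to 45000 nM.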

Compound 3, half-maximal inhibitory concentration: 14300 nM
Beside the measured number, compound 3's estimate is 1.0-fold (0.02 log units) above it; measured number inside the range.
By their numbers in this assay, from the lowest: compounds 1, 3 and 2 (each within the scatter of the next, the first and the last beyond it).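

In this assay, quinolin-8-yl in place of 4-(propoxycarbonyl)phenyl gives a 1.9-fold lower number from compound 2 to compound 3 (0.29 log units; within the scatter) and (quinolin-8-yl)oxy in place of diethylamino gives a 1.2-fold higher number from compound 1 to compound 3 (0.09 log units; within the scatter) with both steps within the scatter. This position therefore accepts a two-ring aromatic group with a ring nitrogen, and compound 3 cannot be told apart from either compound 1 or compound 2, although those two lie beyond the scatter of each other. No measurement available explains these numbers. From the compounds shown here alone, whether the ring nitrogen matters remains open, since naphthalen-1-yl would test it. A carboxylic acid on the aromatic ring is also untested among these compounds.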